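A few compounds are considered here, and "the series" means these few. Any claim that something is new, unique, unknown or untested is made for them only; others in the source may bear on it.

Compound 1 `Cc1cc(C(=O)O)ccc1OCCCCOc1ccc(C(=O)CC(C)C)c(O)c1C` and compound 2 `COc1cc(C(=O)O)ccc1OCCCCOc1ccc(C(=O)CC(C)C)c(O)c1C` share one core. Within the data shown here, in an assay on HEK293 cells for positive allosteric modulation of metabotropic glutamate receptor 2 (Rattus norvegicus), read by thallium flux, with a stated time of 2.5 min (on this read-out lower numbers stand for smaller maximal responses and higher numbers for larger maximal responses), compound 1 gives 83.9%, the lower of the two numbers so far, though the gap lies within the usual scatter, and compound 2 gives 85.7%; the step of a number 1.8 percentage points higher from compound 1 to compound 2 (within the scatter) concerns a methoxy in place of methyl on an aromatic carbon. Compound 3 `CCCC(=O)c1ccc(OCCCCOc2ccc(C(=O)O)cc2C)c(C)c1O` differs from compound 1 by hydrogen in place of methyl on a saturated chain carbon bound to two saturated chain carbons, which cut one bond further out reads isobutylcarbonyl to propylcarbonyl. Among the measured compounds shown here, no measured step touches this chain, so no change beyond the scatter is expected. The expected step is a number 1.9 percentage points lower from compound 1 to compound 3 (within the scatter). Compound 3 is estimated at 82%, with a range from 65% to 98%.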

Compound 3, largest response reached (reported as percent of maximum), in percent of the reference or control that the assay uses: 79.3%
Compound 3: middle estimate off by 2.7 percentage points, on the high side; measured number inside the range.
By their numbers in this assay, from the lowest: compounds 3, 1 and 2 (each within the scatter of the next).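

Cutting isobutylcarbonyl back to propylcarbonyl is the first change shown on this chain, and in this assay it gives a number 4.6 percentage points lower from compound 1 to compound 3 (within the scatter). The methyl on this saturated chain carbon can therefore be lost without a change beyond the scatter, so this chain does not need its branch to keep the maximal response. No supporting data explain this result.

On these data alone, whether a longer chain, such as pentylcarbonyl, would keep the response remains open. So does the outcome of placing an amine on this chain.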